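The source may report more compounds than this note shows. Statements on the series, on what has been measured and on what is new or still open speak of the compounds shown alone.

The measured compounds and their values in this assay:

compound 1 `C[C@@H]1CCCN1c1c(C#N)c2c(N)nc(Nc3cn[nH]c3)nc2n1C` — 0.4 nM
compound 2 `Cn1c(N2CCCC2)c(C#N)c2c(N)ncnc21` — 125 nM
compound 3 `Cc1cn(C)nc1Nc1cc2c(c(N)n1)c(C#N)c(N1CCC[C@H]1C)n2C` — 75 nM

In an assay on isolated protein for binding affinity to Leucine-rich repeat serine/threonine-protein kinase 2 variant G2019S (Homo sapiens), read by TR-FRET and LanthaScreen, with a stated time of 2 h (a higher number here means a weaker inhibitor, a lower number a stronger inhibitor), compound 2 gives 125 nM, the highest number among the three measured compounds. Compound 3 gives 75 nM, a number within the usual scatter of that of compound 2, so the two cannot be told apart. Compound 1 gives 0.4 nM, far lower than compound 2 and well beyond the scatter; compound 1 differs from compound 2 in more than one place, so no single step accounts for that gap, and the same holds for compound 3.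

Compound 4 `CN(C)c1c(C#N)c2c(N)ncnc2n1C` differs from compound 2 in one place only: dimethylamino in place of pyrrolidin-1-yl on an aromatic carbon. Going by the values given here, no pair of measured compounds differs by this change alone, so nothing here measures its size directly. The change removes a ring and leaves a smaller group at the same position; the expectation is a small step from compound 2 to compound 4 of a 2.0-fold higher number from compound 2 to compound 4 (0.30 log units; within the scatter) toward a higher number, though a step within the scatter is also plausible. Compound 4 is therefore estimated at 250 nM in this assay, with a range from 80 nM to 800 nM.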

Compound 4, inhibition constant: 259 nM
The estimate for compound 4 lay 1.0-fold (0.02 log units) below the measured number, and the stated range covers the measured number.
By their numbers in this assay, from the lowest: compound 1; then compounds 3 and 2 (each within the scatter of the next); then compound 4.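

In this assay, going by these compounds alone, replacing pyrrolidin-1-yl with dimethylamino on the aromatic carbon next to the ring nitrogen gives a 2.1-fold higher number from compound 2 to compound 4 (0.32 log units; beyond the scatter); none of the earlier compounds offered a step in one place, so this is the only direct reading of a change at this position. The step is modest: the ring is not required for compound 4 to give 259 nM, though its replacement by dimethylamino costs an amount that lies just beyond the scatter. Nothing measured here accounts for the size of this step.

The compounds shown leave open whether the same change would have a step of similar size in the more elaborate settings of compound 1 and compound 3, which differ from compound 2 in more than one place. Also open, as far as these compounds go, is how this aromatic carbon would respond to other amines, such as piperidin-1-yl, morpholin-4-yl or methylamino, so the two groups compared here mark only a narrow part of what the position might accept.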